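Trimming the propyl chain of compound 1 to methyl

This account rests on a few compounds, and the source may have more. Where it says the series, first, only, none or still open, it means among the compounds named here.

Among the three compounds measured so far, compound 1 `CCCC(C#CC(=O)OC)O/C=C/C(=O)OC` has the lowest number in a functional assay on SW1573 cells (Homo sapiens) for antiproliferative activity, read by sulforhodamine B assay, with a stated time of 48 h (a higher number here means a weaker inhibitor of growth, a lower number a stronger inhibitor of growth), where compound 1 gives 320 nM. In this assay, compound 2 `COC(=O)C#CC(C[C@@H](C)CCC=C(C)C)O/C=C/C(=O)OC` gives 2200 nM and compound 3 `CCCCCCCCCCC(C#CC(=O)OC)O/C=C/C(=O)OC` gives 2000 nM.

Compound 4 `COC(=O)C#CC(C)O/C=C/C(=O)OC` has not yet been measured. The change from the parent is hydrogen in place of ethyl on a saturated chain carbon, two bonds along the chain from an oxygen on an unsaturated carbon and a triple-bonded carbon: hydrogen in place of ethyl, which reads as propyl to methyl.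

For the measured compounds named here, two measured steps bear on this: a 6.9-fold higher number from compound 1 to compound 2 (0.84 log units; beyond the scatter) and a 6.3-fold higher number from compound 1 to compound 3 (0.80 log units; beyond the scatter). Both are modest, lie beyond the scatter and add carbon to the chain, whereas compound 4 loses carbon. They therefore do not settle the direction of this change, and no chain smaller than propyl has been tested. The change is also smaller than either measured step, so no step beyond the scatter is expected in this assay.

The expected change is a 1.4-fold higher number from compound 1 to compound 4 (0.15 log units; within the scatter), slightly upward. For compound 4, the estimate is 450 nM, with an expected range of 150 nM to 1400 nM.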

Compound 4, concentration for 50% growth inhibition: 1700 nM
Compound 4: middle estimate off by 3.8-fold (0.58 log units), on the low side, and the stated range ends below it.
By their numbers in this assay, from the lowest: compound 1; then compounds 4, 3 and 2 (each within the scatter of the next).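

Removing carbon from this chain raises the number just as adding carbon does: in this assay the change from propyl to methyl gives a 5.3-fold higher number from compound 1 to compound 4 (0.73 log units; beyond the scatter) and the two longer chains give a 6.3-fold higher number from compound 1 to compound 3 (0.80 log units; beyond the scatter) and a 6.9-fold higher number from compound 1 to compound 2 (0.84 log units; beyond the scatter). Among the four compounds shown, the number therefore does not move in one direction with chain length, and the propyl chain of compound 1 gives the lowest value, with both shorter and longer chains giving higher numbers. Nothing available here accounts for this rise on shortening.

On these data alone, it remains open how sharp this low point is, since an ethyl or butyl chain on this carbon would lie on either side of propyl. As far as these compounds go, whether a small ring such as cyclopropyl could stand in for propyl also remains unknown.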